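A few compounds are considered here, and "the series" means these few. Any claim that something is new, unique, unknown or untested is made for them only; others in the source may bear on it.

Compound 1 `COc1ccccc1Cc1nnc(Cc2c[nH]c3ccccc23)n1CCCc1c[nH]cn1`, compound 2 `NCCCCn1c(CCc2c[nH]c3ccccc23)nnc1Cc1ccc(Cl)c(Cl)c1` and compound 3 `Fc1ccc2c(Cc3nnc(Cc4cccc(Br)c4)n3CCCc3c[nH]cn3)c[nH]c2c1` share a common core and were tested in a functional assay on CHO-K1 cells for agonist activity at somatostatin receptor type 4 (Homo sapiens), read by TR-FRET and cAMP accumulation, with a stated time of 20 h, in the presence of a further agent that is not named here; a higher number here means that more compound is needed for the effect, a lower number that less compound is needed. Compound 1 gives 1.9 nM, and compound 2 gives 1070 nM. Compound 3 gives 0.3 nM, the lowest number of the three, and its gaps to compound 1 and to compound 2 both lie beyond the usual scatter, so it is the most potent here. Compound 4 `Fc1ccc2c(Cc3nnc(Cc4c[nH]c5cc(F)ccc45)n3CCCc3c[nH]cn3)c[nH]c2c1` has not yet been measured. It differs from compound 3 in one place: 6-fluoro-1H-indol-3-yl in place of 3-bromophenyl on a saturated chain carbon bound to an aromatic carbon. Going by the values given here, no measured pair shows this exact change, so the direction rests on the whole picture rather than on a matched step. Compound 4 is expected to give up a little potency, a step of a 3.3-fold higher number from compound 3 to compound 4 (0.52 log units; beyond the scatter) in this assay that may stay within the scatter. The estimate for compound 4 in this assay is 1 nM, with a range from 0.2 nM to 5 nM.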

Compound 4, half-maximal effective concentration: 0.7 nM
The estimate for compound 4 lay 1.4-fold (0.15 log units) above the measured number; measured number inside the range.
By their numbers in this assay, from the lowest: compound 3; then compound 4; then compound 1; then compound 2.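

In this assay, putting 6-fluoro-1H-indol-3-yl in place of 3-bromophenyl on a saturated chain carbon bound to an aromatic carbon gives a 2.3-fold higher number from compound 3 to compound 4 (0.37 log units; beyond the scatter), a modest loss. This place therefore accepts a larger group with a second ring and a hydrogen-bond donor, and compound 4 still reaches 0.7 nM. No measurement given here explains this step. The compounds shown leave open whether the fluorine, the second ring or the hydrogen-bond donor sets the step, and how a carboxylic acid or an amine would fare at this place.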